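This account rests on a few compounds, and the source may have more. Where it says the series, first, only, none or still open, it means among the compounds named here.

Working notes on the series.

Compound 3 `CCCc1nc(-c2ccccc2)c(CNCCCN2CCN(c3cccc(Cl)c3)CC2)o1` gives 65.9% in an assay on HEK293 cells for inhibition of Voltage-dependent T-type calcium channel subunit alpha-1G (Homo sapiens), read by fluorescence, tested at 10 uM (a higher number here means more inhibition at the concentration tested (going by the name of the read-out), a lower number less inhibition), the largest number among the three measured compounds, though its separation from compound 1 `CCCc1nc(-c2ccccc2)c(CNCCCN2CCN(c3ccc(F)cc3)CC2)o1` is only a number 3.4 percentage points higher from compound 1 to compound 3 (within the scatter), within the scatter, so the two cannot be ordered. Compound 1 gives 62.5% in this assay. The clear separation is from compound 2 `CCCc1nc(-c2ccccc2)c(CNCCCN2CCN(c3cccc(OC)c3)CC2)o1`, which gives 36.4% in this assay; the step is a number 29.5 percentage points higher from compound 2 to compound 3 (beyond the scatter), beyond the scatter, and the companion step is a number 26.1 percentage points lower from compound 1 to compound 2 (beyond the scatter).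

The next compound, compound 4 `CCCc1nc(-c2ccccc2)c(CNCCCN2CCN(c3ccc(C(F)(F)F)cc3)CC2)o1`, differs from compound 3 by 4-(trifluoromethyl)phenyl in place of 3-chlorophenyl on an amine nitrogen in a ring. For the measured compounds named here, two measured steps bear on exchanging the aryl group on the ring nitrogen: the change from 4-fluorophenyl to 3-chlorophenyl moved the number by a number 3.4 percentage points higher from compound 1 to compound 3 (within the scatter), within the scatter, whereas the change from 4-fluorophenyl to 3-methoxyphenyl moved it by a number 26.1 percentage points lower from compound 1 to compound 2 (beyond the scatter), beyond the scatter. Going by the values given here, no measured compound carries a 4-(trifluoromethyl)phenyl group, so the step is open in both directions. Given that the two halogen-bearing aryl groups sit close together and only the methoxy-bearing one falls away, the expectation for compound 4 is a step of a number 5.9 percentage points lower from compound 3 to compound 4 (within the scatter), not beyond the scatter. Compound 4 is therefore estimated at 60%, with a range of 40% to 78%.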

Compound 4, a percentage reported as inhibition, at one concentration (the size of the read-out at that concentration, not a potency): 51.6%
Compound 4: the middle estimate sits 8.4 percentage points above what was measured; measured number inside the range.
By their numbers in this assay, from the lowest: compound 2; then compound 4; then compounds 1 and 3 (each within the scatter of the next).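

In this assay, the aryl group on the amine nitrogen in a ring now separates the halogen-bearing compounds, with a number 14.3 percentage points lower from compound 3 to compound 4 (beyond the scatter) and a number 10.9 percentage points lower from compound 1 to compound 4 (beyond the scatter) marking trifluoromethyl as distinct from the fluoro and chloro groups. The position still does not fall to the level of the 3-methoxyphenyl compound, as a number 15.2 percentage points higher from compound 2 to compound 4 (beyond the scatter) places compound 4 on a middle level, clear of compound 2 on one side and of compounds 1 and 3 on the other. No measurement at hand explains these differences.

The compounds shown leave open whether the lower number of compound 4 follows the trifluoromethyl group itself or its place on the aryl ring, a question that 3-(trifluoromethyl)phenyl and 4-chlorophenyl groups would bear on. Also open, as far as these compounds go, is whether the order holds with a pyridyl group on the ring nitrogen or with a longer chain linking the two amines, and, with one test concentration, how these numbers relate to potency.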